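This account rests on a few compounds, and the source may have more. Where it says the series, first, only, none or still open, it means among the compounds named here.

Compound 2 `C#CCCCOc1ccc2cc(NC(C)=O)c(=O)oc2c1` and compound 1 `C#CCCCOc1ccc2cc(C(=O)OC)c(=O)oc2c1` share one core and differ only in the group on the aromatic carbon: acetamido in compound 2, methoxycarbonyl in compound 1. In an assay on cells for inhibition of Amine oxidase [flavin-containing] B (Homo sapiens), read by Amplex Red, with stated times of 30 min and 45 min (a lower number here means a stronger inhibitor, a higher number a weaker inhibitor), compound 2 gives 43.6 nM, and compound 1 gives 82.4 nM. The step of a 1.9-fold lower number from compound 1 to compound 2 (0.28 log units; within the scatter) is within the scatter, so on the numbers shown the two compounds stand together, compound 2 with the lower figure but not separated from compound 1.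

Compound 3 `CC(=O)Nc1cc2ccc(OCc3cccc(Cl)c3)cc2oc1=O` keeps the acetamido group of compound 2 and changes the other end of the molecule: 3-chlorophenyl in place of but-3-yn-1-yl on a saturated chain carbon bound to an oxygen on an aromatic ring. Going by the values given here, no measured step touches this position; the only step in hand, from compound 1 to compound 2, concerns the group on the aromatic carbon and says nothing about the chain on the ether oxygen. The expectation for compound 3 therefore rests on the structural change alone, with no shown step to scale it, and the number for compound 3 in this assay is estimated as 35 nM, in the range 9 nM to 140 nM. The expected step of a 1.2-fold lower number from compound 2 to compound 3 (0.10 log units; within the scatter) is thus estimated to lie within the scatter, with no direction claimed.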

Compound 3, half-maximal inhibitory concentration: 13.5 nM
The estimate for compound 3 lay 2.6-fold (0.41 log units) above the measured number; measured number inside the range.
By their numbers in this assay, from the lowest: compound 3; then compounds 2 and 1 (each within the scatter of the next).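

In this assay, going by these compounds alone, the ether side chain is the first place where a single change moves the number beyond the scatter: 3-chlorophenyl in place of but-3-yn-1-yl gives a 3.2-fold lower number from compound 2 to compound 3 (0.51 log units; beyond the scatter), a modest step, whereas the change on the aromatic carbon gave a 1.9-fold lower number from compound 1 to compound 2 (0.28 log units; within the scatter) and stayed within it. The position therefore accepts the loss of the triple bond and the entry of a six-membered aromatic ring carrying chlorine, a larger group by the heavy-atom counts, and the number falls rather than rises. No measurement in hand bears on the reason for this step.

On these data alone, the step combines the exchange of the alkyne for an aromatic ring with the arrival of chlorine, so the share of each remains open, and plain benzyl on the ether oxygen would separate them. Also open, as far as these compounds go, is whether 3-chlorobenzyl gives a step of similar size with methoxycarbonyl on the aromatic carbon, and whether fluorine or a methoxy group can take the place of chlorine on the ring.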